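Swapping the aryl group on a shared core

A few compounds are considered here, and "the series" means these few. Any claim that something is new, unique, unknown or untested is made for them only; others in the source may bear on it.

Compound 1, `O=C1N=C(N2CCC[C@H]2C(=O)Nc2ccc3ncnc(Nc4cccc(Cl)c4)c3c2)S/C1=C/c1ccc(Br)s1`, in a functional assay on HepG2 cells (Homo sapiens) for antiproliferative activity, read by MTT assay; on this read-out lower numbers stand for stronger inhibition and higher numbers for weaker inhibition: > 50000 nM, a limit of the assay.
Compound 2, `O=C1N=C(N2CCC[C@H]2C(=O)Nc2ccc3ncnc(Nc4cccc(Cl)c4)c3c2)S/C1=C/c1cccc(Br)c1`, in this assay: 21300 nM.

Going by the values given here, compound 2 holds the only number recorded in this assay; the other entry, for compound 1, is the limit of > 50000 nM in this assay, at which 1 of the 2 values shown sits. Among the compounds with values here, the one measured step, an at least 2.3-fold lower number from compound 1 to compound 2 (0.37 log units; beyond the scatter), shows that changing the aryl group on the double-bonded chain carbon can move the read-out beyond the scatter.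

Compound 3, `O=C1N=C(N2CCC[C@H]2C(=O)Nc2ccc3ncnc(Nc4cccc(Cl)c4)c3c2)S/C1=C/c1ccc2ccccc2n1`, differs from compound 2 by quinolin-2-yl in place of 3-bromophenyl on a double-bonded chain carbon bound to a double-bonded ring carbon. Within the data shown here, no measured step covers this exact exchange, so the only guide is that an aryl swap at this position has already shifted the number once. Since the direction of such a swap cannot be read from a single step, the number for compound 3 is expected to stay near that of compound 2, with a wide range in both directions, and a real chance that only a limit is reported. Compound 3 is therefore estimated at 18000 nM, between 4000 nM and 60000 nM, an expected step of a 1.2-fold lower number from compound 2 to compound 3 (0.07 log units; within the scatter).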

Compound 3, half-maximal inhibitory concentration: 22900 nM
Compound 3: the middle estimate sits 1.3-fold (0.10 log units) below what was measured; measured number inside the range.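

In this assay, exchanging 3-bromophenyl for quinolin-2-yl adds a second six-membered aromatic ring and a ring nitrogen, yet it gives no difference that can be told from the scatter: a 1.1-fold higher number from compound 2 to compound 3 (0.03 log units; within the scatter). At this place on the double-bonded chain carbon, two quite different six-membered aromatic groups therefore give matching numbers, and the step away from 5-bromothiophen-2-yl to quinolin-2-y is of the same kind as the one to 3-bromophenyl: an at least 2.1-fold lower number from compound 1 to compound 3 (0.33 log units; beyond the scatter). Compound 1 stands at a limit of the assay and not at a number: the limit of > 50000 nM in this assay, at which 1 of the 3 values shown sits.

The compounds shown leave open whether the ring nitrogen of quinolin-2-yl and its second ring each count for anything on their own, a question that naphthalen-2-yl, with the same two rings and only carbon in them, would separate. Going by these compounds, it also stays open whether a phenyl ring carrying a carboxylic acid or a dimethylamino group at this place would bring the number away from the level shared by compound 2 and compound 3.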